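From a hydroxyl-bearing chain to an ethynyl group

A few compounds are considered here, and "the series" means these few. Any claim that something is new, unique, unknown or untested is made for them only; others in the source may bear on it.

Measured compounds:
- compound 1, `CCCCNc1nc(N)nc(C)c1CCCC`: 780 nM
- compound 2, `CCCCNc1nc(N)nc(C)c1CCCN(C)C`: 126 nM
- compound 3, `CCCCNc1nc(N)nc(C)c1CCC(C)(C)O`: 3140 nM

The three measured compounds share one core and differ only in the chain on a single aromatic carbon. In an assay on HEK293 cells for agonist activity at Toll-like receptor 8 (Homo sapiens), read by spectrophotometry (a lower number here means that less compound is needed, a higher number that more compound is needed for the effect), compound 3 stands at the highest number of the three, so it needs the most material for the effect. Both steps that lead to it point the same way: a 4.0-fold higher number from compound 1 to compound 3 (0.60 log units; beyond the scatter) and a 25-fold higher number from compound 2 to compound 3 (1.40 log units; beyond the scatter), the second being the larger because the chain of compound 2 carries the dimethylamino group that had lowered the number in a 6.2-fold lower number from compound 1 to compound 2 (0.79 log units; beyond the scatter).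

Compound 4, `C#Cc1c(C)nc(N)nc1NCCCC`, has not yet been measured. The change is ethynyl in place of 3-hydroxy-3-methylbutyl on an aromatic carbon, so the chain that carries one hydrogen-bond donor and one acceptor is replaced by a two-carbon group with neither. For the measured compounds named here, no measured step removes the whole chain; the closest guide is that adding the hydroxyl group in a 4.0-fold higher number from compound 1 to compound 3 (0.60 log units; beyond the scatter) raised the number, so taking it away again is expected to bring the number back down, though the much shorter group makes the size uncertain. On that basis compound 4 is expected to land near the level of compound 1, with a step of about a 2.6-fold lower number from compound 3 to compound 4 (0.42 log units; beyond the scatter) in this assay. The estimate for compound 4 is 1200 nM, with a range from 250 nM to 6000 nM.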

Compound 4, half-maximal effective concentration: 4900 nM
Beside the measured number, compound 4's estimate is 4.1-fold (0.61 log units) below it, and the stated range covers the measured number.
By their numbers in this assay, from the lowest: compound 2; then compound 1; then compounds 3 and 4 (each within the scatter of the next).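

In this assay, exchanging the 3-hydroxy-3-methylbutyl chain for ethynyl gives a 1.6-fold higher number from compound 3 to compound 4 (0.19 log units; within the scatter), so losing the chain's hydrogen-bond donor and acceptor, along with most of its heavy atoms, brings the number no closer to that of the butyl chain. Ethynyl also stands well apart from the two other chains, with a 6.3-fold higher number from compound 1 to compound 4 (0.80 log units; beyond the scatter) and a 39-fold higher number from compound 2 to compound 4 (1.59 log units; beyond the scatter), which shows that this aromatic carbon responds strongly to what is placed on it, yet chain length alone does not settle the number, since compound 3 carries a long chain and still sits within the scatter of compound 4. Nothing available here explains these differences.

The compounds shown leave open how the number moves across the gap between ethynyl and butyl, which a plain ethyl or propyl chain would help to map. They also leave open whether the low number of compound 2 depends on the dimethylamino group itself, or would survive with a primary amine, a carboxylic acid or a shorter 2-(dimethylamino)ethyl chain in its place.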